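One Group Swapped on an Amide-Type Nitrogen

This account rests on a few compounds, and the source may have more. Where it says the series, first, only, none or still open, it means among the compounds named here.

Of the compounds shown here, two that share a core have numbers so far. In a functional assay on KB-V1 cells (Homo sapiens) for cytotoxicity, read by MTT assay, with a stated time of 72 h (on this read-out higher numbers stand for weaker inhibition and lower numbers for stronger inhibition), compound 1 (`O=C1Nc2ccccc2/C1=N/NC(=S)Nc1cccc2ccccc12`) gives 2210 nM and compound 2 (`O=C1Nc2ccccc2/C1=N/NC(=S)NC1CCCCC1`) gives 4380 nM as its result. These two numbers lie within the usual scatter of repeated measurements, so compound 2 stands level with compound 1 on the evidence available.

The next molecule, compound 3 (`O=C1Nc2ccccc2/C1=N/NC(=S)Nc1ccc(Cl)cc1`), has not yet been measured. It carries 4-chlorophenyl in place of cyclohexyl on an amide-type nitrogen and is otherwise the same as compound 2. Among the measured compounds shown here, no measured pair shows this exact swap, so any forecast is rough.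

A large step in this assay is not expected, since the group on that same nitrogen already differs between compound 1 at 2210 nM and compound 2 at 4380 nM with no gap beyond the scatter. The estimated step is a 1.8-fold lower number from compound 2 to compound 3 (0.24 log units; within the scatter) and it leans toward stronger inhibition without clearly leaving the scatter. For compound 3 the estimated value is 2500 nM with 900 nM as the lower end and 6500 nM as the upper end.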

Compound 3, half-maximal inhibitory concentration: 4990 nM
Estimate against measurement, compound 3: 2.0-fold (0.30 log units) below; measured number inside the range.
By their numbers in this assay, from the lowest: compounds 1, 2 and 3 (each within the scatter of the next, the first and the last beyond it).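

Swapping cyclohexyl for 4-chlorophenyl on the amide-type nitrogen gives a 1.1-fold higher number from compound 2 to compound 3 (0.06 log units; within the scatter) in this assay and shows that, at this position, a non-aromatic carbon ring and a chlorine-bearing aromatic ring cannot be told apart by this read-out. Among the compounds shown here, compound 1 at 2210 nM and compound 3 at 4990 nM are the only pair here that lies beyond the scatter, although compound 2 stays within the scatter of both, so the three numbers give only a weak hint that the group on this nitrogen matters. Nothing measured alongside these numbers accounts for the close match between compound 2 and compound 3.

All three groups shown on this nitrogen are bulky carbon rings, which leaves open whether a small methyl group, a longer alkyl chain or a ring bearing an amine or a carboxylic acid would keep the number in the same range. It is also open whether the chlorine matters, since the plain phenyl group, with hydrogen in its place, is not among the compounds shown.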